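This account rests on a few compounds, and the source may have more. Where it says the series, first, only, none or still open, it means among the compounds named here.

Measured compounds in a functional assay on K562 cells (Homo sapiens) for antiproliferative activity, read by resazurin assay, with a stated time of 72 h; a higher number here means a weaker inhibitor, a lower number a stronger inhibitor:
compound 1, `N#Cc1c(-c2ccco2)nc2c(c(-c3ccccc3)nn2-c2ccccc2)c1-c1ccc(O)cc1`: 4200 nM
compound 2, `N#Cc1c(-c2ccc(F)cc2)nc2c(c(-c3ccccc3)nn2-c2ccccc2)c1-c1ccc(O)cc1`: 10200 nM
compound 3, `COc1cc(-c2c(C#N)c(-c3ccco3)nc3c2c(-c2ccccc2)nn3-c2ccccc2)ccc1O`: 24900 nM

Compound 3 stands at the highest number of the three. The step of a 5.9-fold higher number from compound 1 to compound 3 (0.77 log units; beyond the scatter) separates it from compound 1, the lowest number in the set, and the value of compound 2 lies between the other two, lower than that of compound 3.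

Compound 4, `COc1cc(-c2c(C#N)c(-c3ccccc3)nc3c2c(-c2ccccc2)nn3-c2ccccc2)ccc1O`, differs from compound 3 by phenyl in place of furan-2-yl on an aromatic carbon. Going by the values given here, no measured pair shows exactly this exchange. The closest measured step is a 2.4-fold higher number from compound 1 to compound 2 (0.39 log units; beyond the scatter), where a six-membered carbon ring carrying fluorine took the place of the furan-2-yl group at the same position on the core; the number rose modestly there. Whether the fluorine or the ring itself carried that change cannot be separated from the numbers shown. Taking the same exchange on the compound 3 background, a modest rise of the number is expected for compound 4, a 2.0-fold higher number from compound 3 to compound 4 (0.30 log units; within the scatter), in the direction of a weaker inhibitor. Given the high starting value of compound 3, the estimate for compound 4 in this assay is 50000 nM, with a range from 20000 nM to 120000 nM, and there is a real chance that the assay reports only a limit.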

Compound 4, half-maximal inhibitory concentration: > 50000 nM
Compound 4 gave a limit, no number; the forecaster's own chance of this, stated with the estimate: 25%; the middle value lies on the limit itself.
By their numbers in this assay, from the lowest: compound 1; then compound 2; then compound 3. At a limit, above all of these: compound 4.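

In this assay, compound 4 reads > 50000 nM, which is a limit of the assay and not a number. The position next to the ring nitrogen and ortho to a cyano group now has a plain phenyl in place of furan-2-yl, without fluorine, and the step reads an at least 2.0-fold higher number from compound 3 to compound 4 (0.30 log units; that floor lies within the scatter); only a floor is known, and it does not fix the size of the change, but unlike the 4-fluorophenyl step a 2.4-fold higher number from compound 1 to compound 2 (0.39 log units; beyond the scatter) it sits on the 4-hydroxy-3-methoxyphenyl background, and neither exchange away from furan-2-yl gives a lower number. The comparison of compound 4 with compound 3 can go no further than the assay's ceiling: the limit of > 50000 nM in this assay, at which 1 of the 4 values shown sits.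

Still open is how much of the rise from compound 1 to compound 2 belongs to the fluorine and how much to the six-membered ring, since the shown compounds hold no plain phenyl at this position on the 4-hydroxyphenyl background. Also open, on these data alone, is whether this position tolerates anything other than an aromatic ring, such as an amine or a carboxylic acid on a short chain, and whether any such group would bring the number below that of compound 1.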